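The compounds below may be only part of what the source reports. "The series", "measured", "known", "first", "only" and "open" are said of these compounds alone.

Compound 1, `CC(C)(C)c1ccc(NC(=O)c2ccc(OC(F)(F)C(F)F)cc2)cc1`: 70 nM
Compound 2, `CCC(c1ccccn1)c1c(Cl)c(Cl)cc2[nH]c(=O)c(=O)[nH]c12`: 1400 nM
Compound 3, `O=C(NCCN1CCCc2ccccc21)c1ccc(OC(F)(F)F)cc1`: 4600 nM

In a functional assay on HEK293 cells for antagonist activity at transient receptor potential cation channel subfamily V member 1 (Homo sapiens), read by calcium flux (on this read-out higher numbers stand for weaker inhibition and lower numbers for stronger inhibition), compound 3 gives the highest of the three numbers. Compound 2 stands nearest to it, with a lower number that lies beyond the scatter, and compound 1 stands furthest, with a number lower by a wide margin, also beyond the scatter. Compound 4, `COc1ccc2c(c1)N(CCNC(=O)c1ccc(OC(F)(F)F)cc1)CCC2`, differs from compound 3 by a single change: methoxy in place of hydrogen on an aromatic carbon. Among the measured compounds shown here, no measured pair in this set shows what such a change does, so its size cannot be read from the data; the author expects no step beyond the scatter, in either direction. On that basis compound 4 is estimated at 4000 nM in this assay, with a range from 1200 nM to 13000 nM, which would mean an expected step of a 1.2-fold lower number from compound 3 to compound 4 (0.06 log units; within the scatter).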

Compound 4, half-maximal inhibitory concentration: > 10000 nM
Compound 4: only a limit was reported (the forecaster's own chance of this, stated with the estimate: 10%); middle value at least 2.5-fold (0.39 log units) from the limit.
By their numbers in this assay, from the lowest: compound 1; then compound 2; then compound 3. At a limit, above all of these: compound 4.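

Methoxy in place of hydrogen on this aromatic carbon, meta to a fused ring and para to a fused ring, gives in this assay an at least 2.1-fold higher number from compound 3 to compound 4 (0.33 log units; beyond the scatter). Among the compounds shown here, this is the first single change in the set, and it shows that this position does not take methoxy without a loss of inhibition beyond the scatter. The value of compound 4, > 10000 nM, is a limit, so the step gives only a lower bound on the size: the limit of > 10000 nM in this assay, at which 1 of the 4 values shown sits.

Going by these compounds, whether fluorine, hydroxyl or an amine on this carbon would keep the inhibition of compound 3 stays open. So does whether methoxy on the other aromatic carbons of that ring would have the same result.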